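Phenoxy to hydroxy on the biaryl tail

This account rests on a few compounds, and the source may have more. Where it says the series, first, only, none or still open, it means among the compounds named here.

Compound 3 `CC(C)N(Cc1cccc(OCCCCCC(=O)O)c1)C(=O)c1ccc(-c2cccc(Oc3ccccc3)c2)cc1` carries a phenoxy group on the outer ring of the biaryl amide. In an ADME assay on HepG2 cells (Homo sapiens) for cytotoxicity, read by CellTiter-Glo and resazurin assay, with a stated time of 72 h (on this read-out higher numbers stand for an effect only at larger amounts of compound and lower numbers for an effect already at smaller amounts), compound 3 gives > 18700 nM, which is a limit of the assay. The neighbouring compounds sit at limits as well: compound 1 `CC(C)N(Cc1cccc(OCCCCCC(=O)O)c1)C(=O)c1ccc(-c2ccoc2)cc1` gives > 26000 nM, a limit. Compound 2 `CC(C)N(Cc1cccc(OCCCCCC(=O)O)c1)C(=O)c1ccc(-c2ccco2)cc1` gives > 26000 nM, also a limit. Among the compounds with values here, the only step between measured compounds, a step that the two limits leave unreadable from compound 1 to compound 2, is of unreadable size for that reason. The whole set of values rests on two limits: the limit of > 26000 nM in this assay, at which 2 of the 3 values shown sit, and (the limit of > 18700 nM in this assay, at which 1 of the 3 values shown sits).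

Compound 4 `CC(C)N(Cc1cccc(OCCCCCC(=O)O)c1)C(=O)c1ccc(-c2cccc(O)c2)cc1` differs from compound 3 by hydrogen in place of phenyl on an oxygen on an aromatic ring. Within the data shown here, no measured step concerns this exchange, and the single step that exists gives no size. Nothing in the series therefore points to an effect at smaller amounts of compound. The step that the limit leaves unreadable from compound 3 to compound 4 is expected to stay within the scatter, with another limit the likely outcome. Compound 4 is expected to give 30000 nM in this assay, between 15000 nM and 60000 nM.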

Compound 4, half-maximal effective concentration: > 26000 nM
Compound 4 gave a limit, no number (the forecaster's own chance of this, stated with the estimate: 85%); the middle value is on the limit's open side.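

Compound 4 sits at a limit of the assay, and its steps from compound 1, compound 2 and compound 3 cannot be read. The compounds shown leave open at what concentration any of these four takes effect in this assay, and whether phenoxy to hydroxy shifts it.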